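The source may report more compounds than this note shows. Statements on the series, on what has been measured and on what is new or still open speak of the compounds shown alone.

Compound 1 `Nc1ccccc1NC(=O)/C=C/c1ccc(CSc2ccc(F)cc2)cc1`, compound 2 `Nc1ccccc1NC(=O)/C=C/c1ccc(CSCCc2ccccc2)cc1` and compound 3 `Nc1ccccc1NC(=O)c1ccc(CSCCc2ccccc2)cc1` were all tested in a functional assay on A549 cells (Homo sapiens) for inhibition, read by CCK-8 assay, with a stated time of 72 h, tested at 2 uM; a lower number here means less inhibition of growth, a higher number more inhibition of growth at the concentration tested. In this assay compound 1 gives 51.2%, compound 2 gives 45.7% and compound 3 gives 44.9%, so all three sit close together. Compound 2 and compound 1 differ only by 4-fluorophenyl in place of phenethyl on a sulfur, and a number 5.5 percentage points higher from compound 2 to compound 1 (within the scatter). How the core of compound 2 differs from the core of compound 3 is not broken down here. Compound 4 `Nc1ccccc1NC(=O)c1ccc(CSc2ccc(F)cc2)cc1` has not yet been measured; it arises from compound 3 by 4-fluorophenyl in place of phenethyl on a sulfur, the same change at the same place as between compound 2 and compound 1. Since the earlier change gave only a number 5.5 percentage points higher from compound 2 to compound 1 (within the scatter), the step is expected to be a number 5.1 percentage points higher from compound 3 to compound 4 (within the scatter). Compound 4 is therefore estimated to give 50% in this assay, between 38% and 62%.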

Compound 4, percent growth inhibition at one concentration: 43.4%
For compound 4 the middle estimate is 6.6 percentage points above the measured one; measured number inside the range.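

In this assay, 4-fluorophenyl in place of phenethyl on a sulfur gives a number 1.5 percentage points lower from compound 3 to compound 4 (within the scatter). Set beside the earlier step, the two cores cannot be told apart in their response to this change: the same change on two cores in this assay, a number 5.5 percentage points higher (within the scatter) from compound 2 to compound 1 and a number 1.5 percentage points lower (within the scatter) from compound 3 to compound 4, 7 percentage points apart, within the scatter of two such steps This shows that, on these two cores, the change leaves growth inhibition within the scatter at the concentration tested, but it does not show that the two steps are truly equal or that the same would hold on any other core.

The compounds shown leave open whether a different group on the sulfur, such as a plain phenyl, a longer chain or a carboxylic acid, would give a step beyond the scatter. They also leave open how such a group would behave on each of the two cores.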